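The source may hold more compounds than are shown below. What is called first, only, known or untested is meant among the compounds shown, and "the series" means these compounds.

Of the compounds shown here, three have been measured in an assay on isolated protein for inhibition of protein deacetylase HDAC6 (Homo sapiens), read by fluorescence, with stated times of 3 h and 60 min (on this read-out lower numbers stand for stronger inhibition and higher numbers for weaker inhibition), so far. Compound 1, `O=C(NO)c1ccc(CNc2nccc(-c3cccnc3)n2)cc1`, gives 42 nM in this assay. Compound 2, `Nc1ccccc1NC(=O)c1ccc(CNC2=NC(=O)C(Cc3ccccc3)N2)cc1`, returns only a limit of the assay, > 20000 nM. Compound 3, `Nc1cc(C(=O)OCc2ccccc2)ccc1NC(=O)c1ccc(CNc2nccc(-c3cccnc3)n2)cc1`, likewise reaches only a limit, > 20000 nM. Compound 3 therefore stands at the weak end of what has been seen, and it shares this position with compound 2, since two of the three values sit at the limit of > 20000 nM in this assay, at which 2 of the 3 values shown sit. Only compound 1, which carries a hydroxamic acid where the other two carry an anilide, shows a measured number.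

Compound 4, `Nc1cc(Br)ccc1NC(=O)c1ccc(CNc2nccc(-c3cccnc3)n2)cc1`, has not been measured. It differs from compound 3 in one place: bromo in place of benzyloxycarbonyl on an aromatic carbon, meta to an amino group and para to a large group. Going by the values given here, no step between measured compounds is available to calibrate this change, so the expectation rests on the anilide part that compound 4 keeps from compound 3 and compound 2. Compound 4 is expected to remain weak in this assay, with a step that the limit leaves unreadable from compound 3 to compound 4 that does not go beyond the scatter. The estimate for compound 4 is 30000 nM, within a range from 5000 nM to 150000 nM, and the assay will quite possibly report only a limit again.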

Compound 4, half-maximal inhibitory concentration: > 20000 nM
Compound 4 gave a limit, no number; the forecaster's own chance of this, stated with the estimate: 75%; the middle value lies beyond the limit too.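

In this assay compound 4 also returns only a limit, > 20000 nM. The step from benzyloxycarbonyl to bromo cannot be read, since both values are limits, so the most this pair shows is that exchanging a group of 10 heavy atoms for a single bromine on this aromatic carbon does not bring a measurable value into view. The new information lies in the first readable comparison at one place, where 2-amino-4-bromophenyl in place of hydroxy on an amide-type nitrogen gives an at least 470-fold higher number from compound 1 to compound 4 (2.67 log units; beyond the scatter), and the anilide compounds now gather at one boundary of the assay: the limit of > 20000 nM in this assay, at which 3 of the 4 values shown sit.

The compounds shown leave open whether any other group on this aromatic carbon, such as fluoro, methyl or a plain hydrogen, would give a real number with the anilide kept in place. They also leave open what bromo or benzyloxycarbonyl would do in a compound that keeps the hydroxamic acid of compound 1, where a measured value could show a change in either direction.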